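Swapping the Base on a Shared Sugar Core

The compounds below may be only part of what the source reports. "The series", "measured", "known", "first", "only" and "open" are said of these compounds alone.

In a functional assay on MT4 cells (Homo sapiens) for cytotoxicity (on this read-out higher numbers stand for lower toxicity in this test and lower numbers for higher toxicity in this test), compound 1 `CN(C)c1ncnc2c1ncn2[C@@H]1O[C@H](CO[Si](C)(C)C(C)(C)C)[C@@]2(OS(=O)(=O)C=C2N)[C@H]1O[Si](C)(C)C(C)(C)C` gives 15000 nM, the lowest of the two numbers at hand; compound 2 `COc1ccc(C(Nc2ncnc3c2ncn3[C@@H]2O[C@H](CO[Si](C)(C)C(C)(C)C)[C@]3(OS(=O)(=O)C=C3N)[C@H]2O[Si](C)(C)C(C)(C)C)(c2ccccc2)c2ccccc2)cc1` gives 191000 nM in this assay, a gap well beyond the usual scatter, so compound 2 is clearly the less toxic of the pair. Compound 3 `Cn1cnc2c(ncn2[C@@H]2O[C@H](CO[Si](C)(C)C(C)(C)C)[C@@]3(OS(=O)(=O)C=C3N)[C@H]2O[Si](C)(C)C(C)(C)C)c1=O` has not yet been measured in this assay. It differs from compound 1 by a group of 11 heavy atoms (6 carbon, 4 nitrogen, 1 oxygen; one five-membered aromatic ring with 2 hetero atoms, one six-membered aromatic ring with 2 hetero atoms) in place of a group of 12 heavy atoms (7 carbon, 5 nitrogen; one five-membered aromatic ring with 2 hetero atoms, one six-membered aromatic ring with 2 hetero atoms), on a saturated ring carbon, a change that keeps the two-ring shape of the group on the shared core while adding an oxygen and a double bond outside the aromatic rings. For the measured compounds named here, no measured pair isolates this exact exchange, and both known values speak only for the base on the same core. On that basis the step of a 2.0-fold higher number from compound 1 to compound 3 (0.30 log units; within the scatter) in this assay is expected to be modest and more likely upward than downward. For compound 3 the expected value in this assay is 30000 nM, with a range from 8000 nM to 120000 nM.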

Compound 3, half-maximal cytotoxic concentration: > 150000 nM
Compound 3: no number, only a limit (the forecaster's own chance of this, stated with the estimate: 20%); at least 5.0-fold (0.69 log units) between middle value and limit.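

Even on a shared core, the two-ring group on this saturated ring carbon matters: in this assay, the exchange gives an at least 10-fold higher number from compound 1 to compound 3 (1.00 log units; beyond the scatter). The entering and leaving groups have the same aromatic ring types and the same counts of hydrogen-bond donors and acceptors, so those counts alone do not settle the read-out in this pair. Compound 3 gives > 150000 nM, which is a limit of the assay and not a number, so the step has a floor but no known full size: the limit of > 150000 nM in this assay, at which 1 of the 3 values shown sits.

How far the value of compound 3 lies past that limit stays unknown, and a single exchange cannot show which part of the new group accounts for the step. From the compounds shown here alone, whether a primary amine or a chlorine atom on the same ring would move the read-out as far also remains open.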